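Replacing chloro with tert-butyl at an assay limit

The source may report more compounds than this note shows. Statements on the series, on what has been measured and on what is new or still open speak of the compounds shown alone.

In an ADME assay on MRC5 cells (Homo sapiens) for cytotoxicity (on this read-out higher numbers stand for lower toxicity in this test and lower numbers for higher toxicity in this test), compound 1 (`Cc1cn([C@@H]2C[C@H](O)[C@@H](CNC(=O)Nc3ccc(Cl)cc3)O2)c(=O)[nH]c1=O`) gives > 50000 nM as a limit of the assay. Compound 2 (`Cc1ccc2nc(-c3ccc(NC(=O)NC[C@H]4O[C@H](n5cc(C)c(=O)[nH]c5=O)C[C@@H]4O)cc3)sc2c1`) gives > 50000 nM as a limit too. Compound 3 (`Cc1cn([C@@H]2C[C@H](O)[C@@H](CNC(=O)Nc3ccc(OCc4ccc(Cl)cc4)cc3)O2)c(=O)[nH]c1=O`) gives > 50000 nM as a limit as well. Compound 3 therefore stands with the others at the limit of > 50000 nM in this assay, at which 3 of the 3 values shown sit, in this series. Compound 4 (`Cc1cn([C@@H]2C[C@H](O)[C@@H](CNC(=O)Nc3ccc(OCc4ccc(C(C)(C)C)cc4)cc3)O2)c(=O)[nH]c1=O`) carries tert-butyl in place of chloro on an aromatic carbon. The nearest evidence is a step that the two limits leave unreadable from compound 1 to compound 2 together with a step that the two limits leave unreadable from compound 1 to compound 3 and a step that the two limits leave unreadable from compound 2 to compound 3 and none of these has a size that can be read. No step beyond the scatter is therefore expected in this assay from this swap. The estimated change is a number no higher from compound 3 to compound 4 (the limit leaves the size open) with no direction expected. For compound 4 the expected value is 50000 nM within an estimated range of 25000 nM to 100000 nM and a limit of the assay is likely.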

Compound 4, half-maximal cytotoxic concentration: > 50000 nM
Compound 4: only a limit was reported; the forecaster's own chance of this, stated with the estimate: 80%; the middle value lies on the limit itself.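

Compound 4, like compound 1, compound 2 and compound 3, gives only a limit in this assay, so no step among them can be read: the limit of > 50000 nM in this assay, at which 4 of the 4 values shown sit.

The compounds shown leave open how far each lies beyond that limit, and whether tert-butyl in place of chloro changes the read-out at all.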